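The compounds below may be only part of what the source reports. "The series", "measured", "known", "first", "only" and "open" are said of these compounds alone.

Compound 2 `CC1=CC[C@H](C(C)(C)NC(=S)N/N=C/c2cccc(Cl)c2)CC1` carries a 3-chlorophenyl group and in a functional assay on NCI/ADR-RES cells (Homo sapiens) for inhibition, read by sulforhodamine B assay, with a stated time of 48 h (on this read-out higher numbers stand for weaker inhibition of growth and lower numbers for stronger inhibition of growth), compound 2 gives 67500 nM. Within the data shown here, the only other measured compound, compound 1 `CC1=CC[C@H](C(C)(C)NC(=S)N/N=C/c2ccccc2Cl)CC1`, gives 75000 nM in this assay, so the two stand within the scatter of each other, as a 1.1-fold lower number from compound 1 to compound 2 (0.05 log units; within the scatter) shows. Compound 3 `CC1=CC[C@H](C(C)(C)NC(=S)N/N=C/c2ccc(Cl)cc2)CC1` differs from compound 2 by 4-chlorophenyl in place of 3-chlorophenyl on a carbon with a double bond to nitrogen. Among the measured compounds shown here, the one step that bears on this, a 1.1-fold lower number from compound 1 to compound 2 (0.05 log units; within the scatter), moved the chlorine around the same ring without effect beyond the scatter, so no step beyond the scatter is expected here either: a 1.0-fold higher number from compound 2 to compound 3 (0.02 log units; within the scatter). Compound 3 is therefore estimated at 70000 nM in this assay, with a range from 35000 nM to 140000 nM.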

Compound 3, concentration for 50% growth inhibition: 65200 nM
Compound 3: middle estimate off by 1.1-fold (0.03 log units), on the high side, within the range that was stated.
By their numbers in this assay, from the lowest: compounds 3, 2 and 1 (each within the scatter of the next).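

With 4-chlorophenyl in hand, all three chlorophenyl groups in this series can be compared in this assay, and the new steps read a 1.0-fold lower number from compound 2 to compound 3 (0.02 log units; within the scatter) and a 1.2-fold lower number from compound 1 to compound 3 (0.06 log units; within the scatter). At this position, on a carbon with a double bond to nitrogen, the place of the chlorine on the phenyl ring therefore stays within the scatter across compounds 1, 2 and 3, where only one such move could be read before. No measured evidence bears on this result.

Open, from the compounds shown here alone, is whether a methoxy group, a nitrile or an amine on this phenyl ring in place of chlorine, or a second chlorine, would give a step beyond the scatter.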